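This account rests on a few compounds, and the source may have more. Where it says the series, first, only, none or still open, it means among the compounds named here.

Of the compounds shown here, three sharing one core have been measured in a functional assay on MCF7 cells (Homo sapiens) for antiproliferative activity, read by sulforhodamine B assay, with a stated time of 48 h; on this read-out lower numbers stand for stronger inhibition and higher numbers for weaker inhibition. Compound 1 `CC(=O)Nc1ccc(S(=O)(=O)Oc2ccccc2C(C)C)cc1` gives 16000 nM, the second highest of the three numbers. Compound 2 `CC(=O)Nc1ccc(S(=O)(=O)Oc2ccccc2I)cc1` gives 27000 nM, and compound 3 `O=C(NCCCCl)Nc1ccc(S(=O)(=O)Oc2ccccc2I)cc1` gives 7600 nM. The step of a 1.7-fold higher number from compound 1 to compound 2 (0.23 log units; within the scatter) stays within the scatter, whereas the step of a 3.6-fold lower number from compound 2 to compound 3 (0.55 log units; beyond the scatter) is a modest gain in inhibition. Compound 4 `CC(C)c1ccccc1OS(=O)(=O)c1ccc(NC(=O)NCC2CCCC2)cc1` awaits measurement; it differs from compound 1 in one place: (cyclopentylmethyl)amino in place of methyl on a carbonyl carbon. Among the measured compounds shown here, the only measured guide for such a change on the carbonyl carbon is a 3.6-fold lower number from compound 2 to compound 3 (0.55 log units; beyond the scatter), so a modest move toward stronger inhibition is expected, with the new group's size adding uncertainty. Compound 4 is therefore expected to give about 5000 nM, within 1800 nM to 14000 nM, which would be an estimated step of a 3.2-fold lower number from compound 1 to compound 4 (0.51 log units; beyond the scatter).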

Compound 4, half-maximal inhibitory concentration: 7100 nM
Compound 4: middle estimate off by 1.4-fold (0.15 log units), on the low side; low and high end bracket the measured number.
By their numbers in this assay, from the lowest: compounds 4 and 3 (each within the scatter of the next); then compounds 1 and 2 (each within the scatter of the next).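

Swapping methyl on the carbonyl carbon for (cyclopentylmethyl)amino gives a 2.3-fold lower number from compound 1 to compound 4 (0.35 log units; beyond the scatter), a modest gain in inhibition. Among the compounds shown here, until now, the only such change was the chain-bearing a 3.6-fold lower number from compound 2 to compound 3 (0.55 log units; beyond the scatter); this result shows a gain with a group carrying a five-membered non-aromatic ring, and in a compound with isopropyl rather than iodo on the core. No measurement shown explains this gain. As far as these compounds go, it remains open whether the ring or the added amino nitrogen accounts for the step. A plain amino group or a cyclohexylmethylamino group at this carbonyl carbon is also untested in the compounds shown.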